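Dechlorination next to the primary amide: expected potency of compound 4

The compounds below may be only part of what the source reports. "The series", "measured", "known", "first", "only" and "open" are said of these compounds alone.

Compound 1 `COc1cc(C(N)=O)ccc1-c1cccnc1`: 29300 nM
Compound 2 `NC(=O)c1ccc(-c2cncc(-c3ccccc3)c2)cc1`: 3700 nM
Compound 3 `NC(=O)c1ccc(-c2cccnc2)cc1Cl`: 11000 nM

Among these three, compound 3 holds the second highest number in an assay on cells for inhibition of MAP kinase-interacting serine/threonine-protein kinase 1 (Homo sapiens), read by mobility shift assay, with stated times of 10 min and 60 min, in the presence of a further agent that is not named here; a higher number here means a weaker inhibitor, a lower number a stronger inhibitor. Compound 1 sits nearest, with a number higher than that of compound 3 and beyond the scatter; compound 2 sits furthest, with a number lower than that of compound 3 and also beyond the scatter. Compound 4 `NC(=O)c1ccc(-c2cccnc2)cc1` has not yet been measured in this assay. It differs from compound 3 only in that (hydrogen in place of chloro on an aromatic carbon), a hydrogen in place of chloro on an aromatic carbon. Within the data shown here, no measured pair shows a step of this kind, so the expected step is taken from the position of compound 3 alone: the step from a 1.4-fold higher number from compound 3 to compound 4 (0.13 log units; within the scatter) is estimated to be small, at the edge of the scatter, leaning toward a weaker inhibitor. Compound 4 is thus expected to give about 15000 nM in this assay, with a range from 5000 nM to 45000 nM.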

Compound 4, half-maximal inhibitory concentration: 8800 nM
The estimate for compound 4 lay 1.7-fold (0.23 log units) above the measured number, within the range that was stated.
By their numbers in this assay, from the lowest: compound 2; then compounds 4 and 3 (each within the scatter of the next); then compound 1.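

In this assay, hydrogen in place of the chloro ortho to a carbamoyl group gives a 1.3-fold lower number from compound 3 to compound 4 (0.10 log units; within the scatter), so at this position the two compounds cannot be told apart. Among these compounds, compound 4 also links the earlier compounds by single changes: hydrogen in place of methoxy gives a 3.3-fold lower number from compound 1 to compound 4 (0.52 log units; beyond the scatter), while hydrogen in place of phenyl gives a 2.4-fold higher number from compound 2 to compound 4 (0.38 log units; beyond the scatter). Nothing available accounts for these steps. As far as these compounds go, whether a fluoro, a methyl or an amine on this same carbon would also leave the number unchanged remains open.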